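Replacing a Dichlorophenyl Ring with a Dichloropyridinyl Ring

The source may report more compounds than this note shows. Statements on the series, on what has been measured and on what is new or still open speak of the compounds shown alone.

Of the compounds shown here, three have been measured in a physicochemical assay for solubility, read by nephelometry, at pH 2; on this read-out higher numbers stand for higher solubility and lower numbers for lower solubility. Compound 1 `N#Cc1cnc(NC(=O)N2CCN(c3ccc(Cl)c(Cl)c3)CC2)s1` is one of them. In this assay compound 1 gives < 1600 nM, which is a limit of the assay and not a number. Compound 2 `Cc1ccc(N2CCN(C(=O)Nc3ncc(Cl)s3)CC2)cc1Cl` also returns only a limit: in this assay compound 2 gives < 1600 nM. Among the compounds with values here, compound 3 `Clc1cnc2[nH]c(N3CCN(c4cnc(Cl)c(Cl)c4)CC3)nc2c1`, built on a different core, is the one compound with a real reading: in this assay compound 3 gives 25000 nM. Within the data shown here, compound 1 therefore stands at the floor of what has been seen, since two of the three results sit at the limit of < 1600 nM in this assay, at which 2 of the 3 values shown sit, and no step between measured compounds is available.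

Compound 4 `N#Cc1cnc(NC(=O)N2CCN(c3cnc(Cl)c(Cl)c3)CC2)s1` has not yet been measured. It differs from compound 1 in one place: 5,6-dichloropyridin-3-yl in place of 3,4-dichlorophenyl on an amine nitrogen in a ring. The ring keeps its two chlorines but gains one hetero atom and with it one hydrogen-bond acceptor.

Because compound 1 sits at a limit (the limit of < 1600 nM in this assay, at which 2 of the 3 values shown sit), the size of any move cannot be anchored on a number. Still, an upward move beyond the scatter in this assay is expected, with a result at the limit again remaining possible. The expected step is an at least 2.1-fold higher number from compound 1 to compound 4 (0.33 log units; beyond the scatter). Compound 4 is estimated at 3500 nM, within a range from 1000 nM to 14000 nM.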

Compound 4, solubility: < 1600 nM
Compound 4: only a limit was reported (the forecaster's own chance of this, stated with the estimate: 40%); at least 2.1-fold (0.33 log units) between middle value and limit.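

Compound 1 and compound 4 both return only a limit in this assay, so no step between them can be read: the limit of < 1600 nM in this assay, at which 3 of the 4 values shown sit.

The compounds shown leave open whether 5,6-dichloropyridin-3-yl in place of 3,4-dichlorophenyl changes the solubility of compound 1 at all, and if it does, in which direction and by how much.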